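Oral exposure in rat across three related acids

The compounds below may be only part of what the source reports. "The series", "measured", "known", "first", "only" and "open" are said of these compounds alone.

Going by the values given here, compound 2 `CC(C)CC1(O)CCN(C(=O)Nc2cc(Oc3ccc(F)cc3)cc(Oc3ccc(C(C)(C)C(=O)O)cc3)c2)CC1` is one of two compounds measured in an ADME assay on the whole organism for pharmacokinetics, with Rattus norvegicus as the target, with a stated time of 24 h, at a dose of 1 mg/kg by the oral route; a lower number here means less compound in the circulation, a higher number more compound in the circulation at the dose given. In this assay, among the compounds with values here, compound 2 gives 390 ng.h/mL, the lower of the two numbers obtained so far, though its only neighbour sits close by. Compound 1 `CC(C)CC1(O)CCN(C(=O)Nc2cc(Oc3ccc(F)cc3)cc(Oc3ccc(CC(=O)O)cc3)c2)CC1` gives 787 ng.h/mL in this assay, and the step of a 2.0-fold lower number from compound 1 to compound 2 (0.30 log units; within the scatter) stays within the scatter, so the two compounds cannot be ordered on this evidence.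

Compound 3 `CC(C)CC1(O)CCN(C(=O)Nc2cc(Oc3ccc(F)cc3)cc(Oc3ccc(C(=O)O)cc3F)c2)CC1` has not yet been measured in this assay. It differs from compound 2 in one place: 4-carboxy-2-fluorophenyl in place of 4-(1-carboxy-1-methylethyl)phenyl on an oxygen on an aromatic ring. Within the data shown here, only one measured step exists, the one from compound 1 to compound 2, and it concerns the same part of the molecule but a different exchange of groups, so it bears on the present step only loosely; since that step lay within the scatter, the expectation for this assay is a step of no more than modest size, in no firm direction. On that basis compound 3 is expected to give 500 ng.h/mL in this assay, within a range from 150 ng.h/mL to 1600 ng.h/mL. The expected step is therefore a 1.3-fold higher number from compound 2 to compound 3 (0.11 log units; within the scatter).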

Compound 3, area under the concentration-time curve: 83 ng.h/mL
Compound 3: the middle estimate sits 6.0-fold (0.78 log units) above what was measured; the measured number lies below the stated range.
By their numbers in this assay, from the lowest: compound 3; then compounds 2 and 1 (each within the scatter of the next).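

Going by these compounds alone, at this position, on an oxygen on an aromatic ring, the entry of 4-carboxy-2-fluorophenyl gives the first changes beyond the scatter in this assay: in place of 4-(1-carboxy-1-methylethyl)phenyl it gives a 4.7-fold lower number from compound 2 to compound 3 (0.67 log units; beyond the scatter), and in place of 4-(carboxymethyl)phenyl it gives a 9.5-fold lower number from compound 1 to compound 3 (0.98 log units; beyond the scatter). The earlier exchange between the two groups that leave here could not show this, since a 2.0-fold lower number from compound 1 to compound 2 (0.30 log units; within the scatter) stays within the scatter, whereas the new steps show that the group on this oxygen can alter the number obtained, with both going the same way. No measurement shown here accounts for these steps.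

The exchange alters two things at once, since fluorine enters the ring while the carbon count of the group falls, and the compounds shown do not separate these two parts of the change. They also leave open how a ring carrying the carboxylic acid without fluorine would stand, and how a longer chain bearing the acid or an amine in its place would compare on the same core.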